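Adding a Methyl Where Two Limits Gave No Reading

This account rests on a few compounds, and the source may have more. Where it says the series, first, only, none or still open, it means among the compounds named here.

Compound 1 `COc1ccc2nc(C(F)(F)F)cc(OCC(=O)Nc3cc(C)cc(C)c3)c2c1` and compound 2 `CCOc1ccc2nc(C(F)(F)F)cc(OCC(=O)Nc3cc(C)cc(C)c3)c2c1` share one core and differ only in methyl in place of hydrogen on a saturated chain carbon bound to an oxygen on an aromatic ring. In a toxicity assay on HepG2 cells (Homo sapiens) for inhibition, read by CellTiter-Glo, with a stated time of 48 h (a higher number here means a weaker inhibitor, a lower number a stronger inhibitor), compound 1 sits at the boundary of the assay, > 100000 nM, a limit rather than a number. Compound 2 also sits at a limit, > 100000 nM. The step that the two limits leave unreadable from compound 1 to compound 2 cannot be read because the limit of > 100000 nM in this assay, at which 2 of the 3 values shown sit, covers both compounds.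

Compound 3 `COc1ccc2nc(C)cc(OC(C)C(=O)Nc3cc(C)cc(C)c3)c2c1` carries a different core; the difference between the two cores is not broken down here. In this assay, among the compounds with values here, compound 3 gives 39800 nM, the only plain number among the three measured compounds.

Compound 4 `COc1ccc2nc(C)cc(OC(C)(C)C(=O)Nc3cc(C)cc(C)c3)c2c1` is still to be measured and differs from compound 3 in methyl in place of hydrogen on a saturated chain carbon bound to a carbonyl carbon, an oxygen on an aromatic ring and a saturated chain carbon. Within the data shown here, this is the same kind of change as the one from compound 1 to compound 2, but not the same: there the chain carbon was bound to an oxygen on an aromatic ring, here to a carbonyl carbon, an oxygen on an aromatic ring and a saturated chain carbon. Among the measured compounds shown here, the expected step is a 1.3-fold higher number from compound 3 to compound 4 (0.10 log units; within the scatter), resting on nothing firmer than the single reading of compound 3 at 39800 nM and the unreadable earlier step. Compound 4 is estimated at 50000 nM, between 20000 nM and 120000 nM.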

Compound 4, half-maximal inhibitory concentration in the HepG2 assay: > 100000 nM
Compound 4: no number, only a limit; the forecaster's own chance of this, stated with the estimate: 40%; at least 2.0-fold (0.30 log units) between middle value and limit.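

In the HepG2 assay, adding the methyl to the chain carbon on the core of compound 3 gives an at least 2.5-fold higher number from compound 3 to compound 4 (0.40 log units; beyond the scatter), a shift towards weaker inhibition. The reading for compound 4 is a limit and not a number, so this step has no upper end, and the earlier step between compound 1 and compound 2 cannot be read, so nothing shows how a methyl behaves on the core of compound 1: the limit of > 100000 nM in the HepG2 assay, at which 3 of the 4 values shown sit. In a physicochemical assay for lipophilicity, read by HPLC, in phosphate buffer, measured as chromatographic lipophilicity, at pH 7.4 (on this read-out higher numbers stand for higher lipophilicity and lower numbers for lower lipophilicity), the same change on the core of compound 3 comes with higher lipophilicity, but this rests on a single pair of compounds: the measured distribution coefficient of compound 3, 5.76, and of compound 4, 6.37, a number 0.61 log units higher (beyond the scatter). In the physicochemical assay compound 3 gives 5.76 and compound 4 gives 6.37.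

The compounds shown leave open whether a methyl on this chain carbon would give a readable step on the core of compound 1. They also leave open how an amine or a carboxylic acid at this place would read in the HepG2 assay.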